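Swapping the amine ring beside a methoxymethyl group

The source may report more compounds than this note shows. Statements on the series, on what has been measured and on what is new or still open speak of the compounds shown alone.

Measured in a functional assay on MES-SA/Dx5 cells (Homo sapiens) for inhibition, with a stated time of 72 h, in the presence of a further agent that is not named here (a higher number here means a weaker inhibitor, a lower number a stronger inhibitor), the compounds read:
compound 1 `Oc1c(CN2CCCCC2)ccc2cccnc12` gives 2690 nM; 2750 nM (2 entries) as two entries
compound 2 `Oc1c(CN2CCCC2)cc(Br)c2cccnc12` gives 2690 nM as one entry
compound 3 `COCc1cc(CN2CCCC2)c(O)c2ncccc12` gives 3550 nM as one entry

Methoxymethyl in place of bromo gives a 1.3-fold higher number from compound 2 to compound 3 (0.12 log units; within the scatter) so compound 3 stands level with its nearest neighbour. Among the measured compounds shown here, compound 4 `COCc1cc(CN2CCCCC2)c(O)c2ncccc12` departs from compound 3 by piperidin-1-yl in place of pyrrolidin-1-yl on a saturated chain carbon bound to an aromatic carbon and no measured step isolates this swap. The entries of compound 1 agree closely (the several entries of compound 1 in this assay, 2690 nM; 2750 nM (2 entries)) and this compound, which has piperidin-1-yl but no methoxymethyl, reads 2690 nM; 2750 nM (2 entries) against compound 3 at 3550 nM in this assay without a wide gap. No shift beyond the scatter is therefore expected, the expected change being a 1.2-fold lower number from compound 3 to compound 4 (0.07 log units; within the scatter) and no more. Compound 4 is estimated at 3000 nM with an expected range of 1500 nM to 6000 nM in this assay.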

Compound 4, half-maximal inhibitory concentration: 7590 nM
Compound 4: middle estimate off by 2.5-fold (0.40 log units), on the low side; measured number above the stated range.
By their numbers in this assay, from the lowest: compounds 2 and 3 (each within the scatter of the next); then compound 4.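

In this assay, piperidin-1-yl in place of pyrrolidin-1-yl gives a 2.1-fold higher number from compound 3 to compound 4 (0.33 log units; beyond the scatter), whereas the earlier change of bromo to methoxymethyl stayed within the scatter. The amine ring on this saturated chain carbon bound to an aromatic carbon therefore affects the reading, though only modestly. Repeat readings in this assay can agree closely: the several entries of compound 1 in this assay, 2690 nM; 2750 nM (2 entries)

As far as these compounds go, whether the swap would have the same size with bromo in place of methoxymethyl remains open. So does how a morpholine ring or an open-chain diethylamino group would read at this place.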